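The source may report more compounds than this note shows. Statements on the series, on what has been measured and on what is new or still open speak of the compounds shown alone.

Within the data shown here, only two compounds sharing one core have numbers so far. In a functional assay on A549 cells (Homo sapiens) for inhibition, read by MTT assay, with a stated time of 72 h (a higher number here means a weaker inhibitor, a lower number a stronger inhibitor), compound 1 `COc1cc(O)c(CC=C(C)C)c(O)c1C(=O)/C=C/c1ccc(O)c(O)c1` gives 16100 nM, and compound 2 `COc1cc(O)c(CC=C(C)C)c(O)c1C(=O)/C=C/c1ccc(Cl)cc1` gives 11800 nM. These two values lie within the usual scatter of each other, so compound 2 cannot be ranked ahead of compound 1 or behind it.

The next compound, compound 3 `COc1cc(O)c(CC=C(C)C)c(O)c1C(=O)/C=C/c1ccc([N+](=O)[O-])cc1`, keeps the shared core and has nitro in place of chloro on an aromatic carbon, turning 4-chlorophenyl into 4-nitrophenyl: nitro in place of chloro on an aromatic carbon. Among the measured compounds shown here, no measured step makes this exact swap. The closest guide is a 1.4-fold lower number from compound 1 to compound 2 (0.13 log units; within the scatter), which changes the same phenyl group, with 4-chlorophenyl in place of 3,4-dihydroxyphenyl, and stays within the scatter. One small step is thin evidence, but it gives no reason to expect a large move here. A similarly small step, with no firm direction, is therefore expected in this assay. The estimated change is a 1.1-fold lower number from compound 2 to compound 3 (0.03 log units; within the scatter), which would also stay within the scatter. For compound 3 the expected value is 11000 nM, with an estimated range from 5000 nM to 25000 nM.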

Compound 3, half-maximal inhibitory concentration: 31200 nM
Compound 3: the middle estimate sits 2.8-fold (0.45 log units) below what was measured; the whole stated range lies below it.
By their numbers in this assay, from the lowest: compounds 2, 1 and 3 (each within the scatter of the next, the first and the last beyond it).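

Among these compounds, replacing chloro with nitro on this aromatic carbon gives the first step in this assay that lies beyond the scatter: a 2.6-fold higher number from compound 2 to compound 3 (0.42 log units; beyond the scatter). This modest step shows that the group on this carbon can shift the number, and that this particular exchange moves it toward a weaker inhibitor. The comparison with the catechol-like starting point reads differently, since a 1.9-fold higher number from compound 1 to compound 3 (0.29 log units; within the scatter) stays within the scatter, so 4-nitrophenyl and 3,4-dihydroxyphenyl cannot be ranked against each other, and no data here explain why chloro, with its single heavy atom, and nitro, with three heavy atoms and two hydrogen-bond acceptors, differ in this way.

As far as these compounds go, three phenyl groups are too few to show what governs the number at this place, so it remains open how an amine, a carboxylic acid or a simple methyl group on the same aromatic carbon would read. From the compounds shown here alone, all three compounds also keep the rest of the shared core unchanged, so it is equally open whether this step would keep its size and direction if another part of the core carried a longer chain.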